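The source may hold more compounds than are shown below. What is called first, only, known or untested is meant among the compounds shown, and "the series" means these compounds.

Two compounds have numbers in an assay on CHO cells for displacement of a labelled ligand from adenosine receptor A1 (Homo sapiens), read by scintillation counting (a higher number here means a weaker inhibitor, a lower number a stronger inhibitor), so far. Compound 1 `COc1ccc(CCc2nc(N)c3nn(-c4ccccc4)cc3n2)cc1` gives 380 nM. For the measured compounds named here, compound 2 `Nc1nc(CCCc2ccccc2)nc2cn(-c3ccccc3)nc12` gives 5.31 nM, the lowest of the two numbers; the single change between them, benzyl in place of 4-methoxyphenyl on a saturated chain carbon, two bonds along the chain from an aromatic carbon, produced a 72-fold lower number from compound 1 to compound 2 (1.85 log units; beyond the scatter). Compound 3 `COc1cccc(CCCc2nc(N)c3nn(-c4ccccc4)cc3n2)c1` has not yet been measured in this assay. It differs from compound 2 by methoxy in place of hydrogen on an aromatic carbon, a change that reads as phenyl to 3-methoxyphenyl when cut one bond further out. Going by the values given here, only the step from compound 1 to compound 2 bears on it, and only loosely: there the methoxy was part of a 4-methoxyphenyl group, not a 3-methoxyphenyl group, so its large size cannot simply be carried over. That step moved the number far down as a methoxy left; a methoxy entering on an aromatic carbon is therefore expected to raise the number, though less sharply. A modest rise is expected, estimated as a 2.3-fold higher number from compound 2 to compound 3 (0.35 log units; beyond the scatter). Compound 3 is accordingly expected to give 12 nM, with a range from 4 nM to 40 nM.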

Compound 3, inhibition constant: 0.15 nM
Compound 3: middle estimate off by 80-fold (1.90 log units), on the high side; the whole stated range lies above it.
By their numbers in this assay, from the lowest: compound 3; then compound 2; then compound 1.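

In this assay, placing a methoxy on this aromatic carbon, meta to a large group, gives a 35-fold lower number from compound 2 to compound 3 (1.55 log units; beyond the scatter), so at this place on the ring the added methoxy goes with a stronger inhibitor, not a weaker one. For the compounds shown here, compound 1 was the only earlier compound with a methoxy, held within a 4-methoxyphenyl group, so the high number of compound 1 cannot be pinned on the presence of a methoxy as such; the comparison of the whole groups gives a 2500-fold lower number from compound 1 to compound 3 (3.40 log units; beyond the scatter), which shows how much depends on the group that carries the methoxy and on where the methoxy sits. No measurement here explains why this methoxy has so large an effect.

On these data alone, it remains open whether the gain belongs to methoxy in particular, or whether an ethoxy, a hydroxyl or a chlorine on the same aromatic carbon would also lower the number. As far as these compounds go, it also remains open how a 4-methoxybenzyl group would compare with the 3-methoxybenzyl group of compound 3, which would separate the place of the methoxy from the rest of the change.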